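Chloro in place of nitro on compound 2

The source may report more compounds than this note shows. Statements on the series, on what has been measured and on what is new or still open speak of the compounds shown alone.

Going by the values given here, in a functional assay on HCT-116 cells (Homo sapiens) for inhibition, read by MTT assay, with a stated time of 48 h (on this read-out higher numbers stand for weaker inhibition and lower numbers for stronger inhibition), compound 2 (`COc1ccc(CNc2cc(OC)c(OC)c(OC)c2)cc1[N+](=O)[O-]`) gives 18200 nM, the highest of the three numbers measured so far and thus the weakest inhibition among them. Compound 1 (`C/C=C/C(=O)N(Cc1ccc(OC)c([N+](=O)[O-])c1)c1cc(OC)c(OC)c(OC)c1`) gives 670 nM, and compound 3 (`COc1ccc(CN(C(C)=O)c2cc(OC)c(OC)c(OC)c2)cc1O`) gives 270 nM. Among the compounds with values here, no step that isolates a single change connects compound 3 with the other two.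

The next compound, compound 4 (`COc1ccc(CNc2cc(OC)c(OC)c(OC)c2)cc1Cl`), departs from compound 2 in one place: chloro in place of nitro on an aromatic carbon. This is chloro in place of nitro on an aromatic carbon, ortho to a methoxy group and meta to a large group.

Within the data shown here, only one measured step is available, a 27-fold higher number from compound 1 to compound 2 (1.43 log units; beyond the scatter). It is large and beyond the scatter, but it is hydrogen in place of (prop-1-en-1-yl)carbonyl on a nitrogen, not a change on this aromatic carbon, and so it offers no direct guide. Among the measured compounds shown here, no measured step touches the nitro group, and no shift beyond the scatter is expected in either direction in this assay. The expectation rests on compound 2 at 18200 nM alone. The estimated change is small, a 1.2-fold lower number from compound 2 to compound 4 (0.08 log units; within the scatter). Compound 4 is expected at 15000 nM, with an estimated range from 5000 nM to 45000 nM.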

Compound 4, half-maximal inhibitory concentration: 41700 nM
The estimate for compound 4 lay 2.8-fold (0.44 log units) below the measured number; low and high end bracket the measured number.
By their numbers in this assay, from the lowest: compound 3; then compound 1; then compound 2; then compound 4.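

In this assay, going by these compounds alone, the pair gives the first direct reading of this aromatic carbon, ortho to a methoxy group and meta to a large group: chloro in place of nitro gives a 2.3-fold higher number from compound 2 to compound 4 (0.36 log units; beyond the scatter), a modest step beyond the scatter towards weaker inhibition. The position therefore responds to this exchange, although the step is much smaller than the one seen on the nitrogen, a 27-fold higher number from compound 1 to compound 2 (1.43 log units; beyond the scatter). No measurement at hand accounts for the difference between nitro and chloro on this carbon, so the step stands as an observation without an explanation.

Going by these compounds, it remains open how an amine, a nitrile or a fluoro group on this carbon would compare with nitro and chloro, and whether the step would keep its size and direction with (prop-1-en-1-yl)carbonyl on the nitrogen in place of hydrogen. Compound 3 carries a hydroxy group on this carbon, but it differs from compound 2 and compound 4 in more than one place, so its value cannot show what that group contributes.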